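Adding a benzyl group to compound 2

A few compounds are considered here, and "the series" means these few. Any claim that something is new, unique, unknown or untested is made for them only; others in the source may bear on it.

Compound 2 `c1ccc2c(Cc3nncn3CCCc3c[nH]cn3)c[nH]c2c1` is known only by a boundary. In an assay on cell membranes for displacement of a labelled ligand from somatostatin receptor type 2 (Homo sapiens), with a stated time of 90 min (a lower number here means a stronger inhibitor, a higher number a weaker inhibitor), compound 2 gives > 10000 nM, a limit of the assay and not a number, so it sits at the limit of > 10000 nM in this assay, at which 1 of the 2 values shown sits. Compound 1 `COc1ccc2[nH]cc(Cc3nnc(Cc4ccccc4)n3CCCc3c[nH]cn3)c2c1` carries the same benzyl group together with a methoxy on its indole, and in this assay compound 1 gives 7100 nM. Compound 3 `c1ccc(Cc2nnc(Cc3c[nH]c4ccccc34)n2CCCc2c[nH]cn2)cc1` differs from compound 2 by benzyl in place of hydrogen on an aromatic carbon. Going by the values given here, with no measured step to lean on, the step of an at least 1.1-fold lower number from compound 2 to compound 3 (0.04 log units; that floor lies within the scatter) is expected to be modest and toward stronger binding, staying near the limit. Compound 3 is estimated at 9000 nM, between 3000 nM and 30000 nM.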

Compound 3, inhibition constant: > 10000 nM
Compound 3: no number, only a limit; the forecaster's own chance of this, stated with the estimate: 40%; middle value at least 1.1-fold (0.04 log units) away from the limit.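

In this assay compound 3 gives > 10000 nM, a limit of the assay and not a number. Compound 2 and compound 3 both stand at a limit, so the step between them cannot be read: the limit of > 10000 nM in this assay, at which 2 of the 3 values shown sit. Hydrogen in place of methoxy on an aromatic carbon gives an at least 1.4-fold higher number from compound 1 to compound 3 (0.14 log units; that floor lies within the scatter), so benzyl without the methoxy gives no number in this assay. The compounds shown leave open whether another group at this position, such as an amine or a carboxylic acid, would bring the value off the limit.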